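A few compounds are considered here, and "the series" means these few. Any claim that something is new, unique, unknown or untested is made for them only; others in the source may bear on it.

Measured so far:
Compound 1 `COc1cc(NC(C)CCCNC(=O)NCCO)c2ncccc2c1` — in an ADME assay on L6 cells (Rattus norvegicus) for cytotoxicity, read by resazurin assay, with a stated time of 70 h (on this read-out lower numbers stand for stronger inhibition and higher numbers for weaker inhibition), compound 1 gives "not determined" (no result reported).
Compound 2 `COc1cc(NC(C)CCCNC(=O)NNC(=O)/C(C)=C/c2ccccc2)c2ncccc2c1` — in this assay compound 2 gives 36500 nM.

Among the measured compounds shown here, compound 2 thus holds the only number on record, while compound 1 stands without one. Compound 3 `COc1cc(NC(C)CCCNC(=O)NNC(=O)/C=C/c2ccccc2F)c2ncccc2c1` has not been measured yet. It differs from compound 2 in a single place: 2-(2-fluorophenyl)ethenyl in place of 1-methyl-2-phenylethenyl on a carbonyl carbon. For the measured compounds named here, no step between measured compounds is available to guide the expectation, so a change of this kind is expected to stay within the usual scatter in this assay, with no clear direction, and the expected step is a 1.1-fold lower number from compound 2 to compound 3 (0.06 log units; within the scatter). Compound 3 is expected to give 32000 nM, with a range from 12000 nM to 85000 nM.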

Compound 3, half-maximal inhibitory concentration: 25100 nM
Beside the measured number, compound 3's estimate is 1.3-fold (0.11 log units) above it; the range from low to high includes it.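

Exchanging 1-methyl-2-phenylethenyl for 2-(2-fluorophenyl)ethenyl on a carbonyl carbon gives a 1.5-fold lower number from compound 2 to compound 3 (0.16 log units; within the scatter) in this assay, the first step available at this position. The methyl group leaves and a fluorine enters in the same change, so this step cannot separate what each does alone. No measurement on hand offers an explanation for the step. From the compounds shown here alone, it remains open whether an amine or a carboxylic acid on the phenyl ring, or a longer chain in place of the ethenyl link, would move the number beyond the scatter.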